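The source may report more compounds than this note shows. Statements on the series, on what has been measured and on what is new or still open speak of the compounds shown alone.

Measured compounds:
compound 1 `Cc1ccc(-n2cc(CN3C(=O)C[C@@H]4CC[C@@]3(C)C4(C)C)nn2)cc1` – 480 nM
compound 2 `CC1(C)[C@H]2CC[C@]1(C)N(Cc1cn(-c3ccccc3C#N)nn1)C(=O)C2` – 180 nM
compound 3 `CC1(C)[C@H]2CC[C@]1(C)N(Cc1cn(-c3cccc(F)c3)nn1)C(=O)C2` – 80 nM

The three share one core and differ only in the aryl group on an aromatic nitrogen. In a functional assay on HepG2 cells (Homo sapiens) for inhibition, read by MTT assay, with a stated time of 24 h (a lower number here means a stronger inhibitor, a higher number a weaker inhibitor), compound 1 gives 480 nM, the highest of the three numbers. Compound 2 gives 180 nM and compound 3 gives 80 nM. Both steps away from compound 1 are beyond the scatter: a 2.7-fold lower number from compound 1 to compound 2 (0.43 log units; beyond the scatter) and a 6.0-fold lower number from compound 1 to compound 3 (0.78 log units; beyond the scatter). The two substituted phenyls also differ from each other, a 2.3-fold lower number from compound 2 to compound 3 (0.35 log units; beyond the scatter), again beyond the scatter.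

Compound 4 `COc1cccc(-n2cc(CN3C(=O)C[C@@H]4CC[C@@]3(C)C4(C)C)nn2)c1` has not yet been measured. It differs from compound 1 in one place:
3-methoxyphenyl in place of 4-methylphenyl on an aromatic nitrogen

Both measured steps from compound 1 bear on this change, as each also removes the 4-methylphenyl and puts in a differently substituted phenyl, and both gave a modest drop in the number. The nearest analogue is compound 3, where a 3-fluorophenyl stands in the same place and gives 80 nM. For compound 4 a modest drop in this assay is therefore expected, of about a 2.4-fold lower number from compound 1 to compound 4 (0.38 log units; beyond the scatter). Compound 4 is estimated at 200 nM, with a likely range from 80 nM to 550 nM.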

Compound 4, half-maximal inhibitory concentration: 70 nM
Estimate against measurement, compound 4: 2.9-fold (0.46 log units) above; the whole stated range lies above it.
By their numbers in this assay, from the lowest: compounds 4 and 3 (each within the scatter of the next); then compound 2; then compound 1.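

The step from 4-methylphenyl to 3-methoxyphenyl on the aromatic nitrogen in this assay (a 6.9-fold lower number from compound 1 to compound 4 (0.84 log units; beyond the scatter)) shows that the drop seen with 3-fluorophenyl is not confined to that one group, and methoxy in place of fluoro on the aromatic carbon leaves the number unchanged within the scatter (a 1.1-fold lower number from compound 3 to compound 4 (0.06 log units; within the scatter)). Compound 3 and compound 4 therefore stand level, and neither can be ranked over the other. The 3-methoxyphenyl group also separates from 2-cyanophenyl (a 2.6-fold lower number from compound 2 to compound 4 (0.41 log units; beyond the scatter)), which matches in direction the step already seen with 3-fluorophenyl (a 2.3-fold lower number from compound 2 to compound 3 (0.35 log units; beyond the scatter)), so that the three changes at this place now give more than one level of activity. Nothing available explains these differences.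

From the compounds shown here alone, whether a longer chain such as ethoxy, or an amine or a carboxylic acid, on the same aromatic carbon would hold the number at this level remains open, as does the standing of unsubstituted phenyl against these groups. Going by these compounds, all values here also come from a single cell line and one read-out, so whether the same order holds in other cells stays open.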